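A few compounds are considered here, and "the series" means these few. Any claim that something is new, unique, unknown or untested is made for them only; others in the source may bear on it.

Of the compounds shown here, three built on one shared core have been tested in a functional assay on IMR-32 cells (Homo sapiens) for cytotoxicity, read by sulforhodamine B assay, with a stated time of 48 h; on this read-out higher numbers stand for weaker inhibition and lower numbers for stronger inhibition. Compound 1 `CC1=C(/C=C/C(=O)/C=C/c2ccc(F)cc2)C(C)(C)CCC1` gives 7400 nM in this assay. Compound 2 `CC1=C(/C=C/C(=O)/C=C/c2ccc(C#N)cc2)C(C)(C)CCC1` gives 23400 nM, and compound 3 `COc1ccc(/C=C/C(=O)/C=C/C2=C(C)CCCC2(C)C)cc1` gives 23900 nM. Compound 1 therefore stands with the lowest number of the three, and both other compounds lie beyond the scatter from it: a 3.2-fold higher number from compound 1 to compound 2 (0.50 log units; beyond the scatter), and a 3.2-fold higher number from compound 1 to compound 3 (0.51 log units; beyond the scatter). Compound 2 and compound 3 sit close to each other, since a 1.0-fold higher number from compound 2 to compound 3 (0.01 log units; within the scatter).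

Compound 4 `CC1=C(/C=C/C(=O)/C=C/c2ccoc2)C(C)(C)CCC1` has not yet been measured. Set against compound 1, the difference is furan-3-yl in place of 4-fluorophenyl on a double-bonded chain carbon bound to a double-bonded chain carbon. Among the compounds with values here, no measured step replaces the whole aromatic ring at this position; the two steps that start from compound 1 only exchange the group carried on that ring, and each one raised the number by a modest amount. With those two steps as the nearest guide, a step of similar size in the same direction is expected, though the uncertainty is wider here because the entire ring is exchanged. In this assay compound 4 is estimated at 15000 nM, with a range from 5000 nM to 50000 nM. That estimate means a step of a 2.0-fold higher number from compound 1 to compound 4 (0.31 log units; beyond the scatter) is expected.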

Compound 4, half-maximal inhibitory concentration: 56800 nM
Estimate against measurement, compound 4: 3.8-fold (0.58 log units) below, outside the stated range (above it).
By their numbers in this assay, from the lowest: compound 1; then compounds 2 and 3 (each within the scatter of the next); then compound 4.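

In this assay, exchanging the whole ring at this position has a larger effect than any change shown so far to the group on the ring: furan-3-yl in place of 4-fluorophenyl gives a 7.7-fold higher number from compound 1 to compound 4 (0.89 log units; beyond the scatter), while the earlier exchanges gave a 3.2-fold higher number from compound 1 to compound 2 (0.50 log units; beyond the scatter) and a 3.2-fold higher number from compound 1 to compound 3 (0.51 log units; beyond the scatter). All three changes from compound 1 therefore raise the number, so none of them gives stronger inhibition than the 4-fluorophenyl group in this small set. Nothing available here accounts for the size of this step.

Compound 4 differs from compound 1 in several ways at once, as its ring is five-membered, contains an oxygen atom and lacks the fluorine, so these compounds cannot show which of these differences matters. An unsubstituted phenyl ring would test the role of the fluorine alone, while a thiophen-3-yl or furan-2-yl group would help separate the effects of the ring atom and the point of attachment from that of ring size.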